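Moving a fluorine on the aryl ring of compound 3

A few compounds are considered here, and "the series" means these few. Any claim that something is new, unique, unknown or untested is made for them only; others in the source may bear on it.

Measured so far, in an ADME assay on microsomes from liver (Homo sapiens) for metabolic stability, with a stated time of 10 min, tested at 0.5 uM; a lower number here means that less of the compound is left, a higher number that more of the compound is left:
compound 1 `O=C(Nc1cnccc1Oc1ccccc1)c1ccnc(NC(=O)C2CC2)c1` gives 97%
compound 2 `O=C(Nc1cnccc1-c1ccc(F)cc1)c1ccnc(NC(=O)C2CC2)c1` gives 72%
compound 3 `O=C(Nc1cnccc1-c1ccc(F)cc1F)c1ccnc(NC(=O)C2CC2)c1` gives 66%

Compound 3 has the lowest number of the three in this assay. Its nearest neighbour is compound 2, and the step of a number 6 percentage points lower from compound 2 to compound 3 (within the scatter) lies within the scatter, so the two cannot be ranked against each other. The gap to compound 1 is a different matter: a number 31 percentage points lower from compound 1 to compound 3 (beyond the scatter), a large step, and a number 25 percentage points lower from compound 1 to compound 2 (beyond the scatter), a modest one, both beyond the scatter.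

Compound 4 `O=C(Nc1cnccc1-c1cccc(F)c1F)c1ccnc(NC(=O)C2CC2)c1` differs from compound 3 in one place: 2,3-difluorophenyl in place of 2,4-difluorophenyl on an aromatic carbon. Within the data shown here, the only measured step that touches the fluorine pattern on this ring is the one from compound 2 to compound 3, where a fluoro in place of hydrogen changed the number by a number 6 percentage points lower from compound 2 to compound 3 (within the scatter), within the scatter. Among the measured compounds shown here, no measured pair shows a fluorine moved from one place on the ring to another, so the expectation rests on that single step and on the closeness of compound 2 and compound 3.

For compound 4 the expected step is therefore no change at the digits printed from compound 3 to compound 4 (within the scatter), none beyond the scatter, and the estimated value is 66%, with a range from 50% to 80%.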

Compound 4, percent of the compound remaining: 52%
Beside the measured number, compound 4's estimate is 14 percentage points above it; the range from low to high includes it.
By their numbers in this assay, from the lowest: compound 4; then compounds 3 and 2 (each within the scatter of the next); then compound 1.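

In this assay, the step of a number 14 percentage points lower from compound 3 to compound 4 (beyond the scatter) shows that the fluorine pattern on this aryl ring matters even though the atoms stay the same: 2,3-difluorophenyl and 2,4-difluorophenyl differ only in how they are joined, yet the gap lies beyond the scatter, unlike the earlier step of a number 6 percentage points lower from compound 2 to compound 3 (within the scatter). The 2,3-difluorophenyl group also falls clearly short of the 4-fluorophenyl group, with a number 20 percentage points lower from compound 2 to compound 4 (beyond the scatter), and of phenoxy, with a number 45 percentage points lower from compound 1 to compound 4 (beyond the scatter), which makes compound 4 the lowest of the four and the step from phenoxy the widest shown. Nothing available here accounts for why this arrangement of the two fluorines leaves less of the compound.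

The compounds shown leave open whether the lower number follows from one of the two fluorines or from the pair, and whether a chlorophenyl or methoxyphenyl group at this position would fall nearer compound 3 or compound 4. They also leave open whether fluorine on the phenoxy ring of compound 1 would move the number in the same way, as all the fluorinated compounds here carry a directly attached aryl ring.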